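The source may hold more compounds than are shown below. What is called first, only, known or untested is meant among the compounds shown, and "the series" means these compounds.

Compound 1 `O=C(OC1CCC(CN2CCN(c3cc(=O)c4cc(C(F)(F)F)cc([N+](=O)[O-])c4s3)CC2)CC1)c1ccccc1`: > 64 ug/mL
Compound 2 `O=C(OC1CCC(CN2CCN(c3cc(=O)c4cc(C(F)(F)F)cc([N+](=O)[O-])c4s3)CC2)CC1)c1ccc(F)cc1`: > 64 ug/mL

In an ADME assay on Vero cells (Chlorocebus sabaeus) for cytotoxicity, read by MTT assay, with a stated time of 48 h (a higher number here means a weaker inhibitor, a lower number a stronger inhibitor), compound 2 gives > 64 ug/mL, which is a limit of the assay and not a number. Compound 1 gives > 64 ug/mL, which is also a limit. Neither measured compound has left that limit: the limit of > 64 ug/mL in this assay, at which 2 of the 2 values shown sit. Compound 3 `COc1ccc(C(=O)OC2CCC(CN3CCN(c4cc(=O)c5cc(C(F)(F)F)cc([N+](=O)[O-])c5s4)CC3)CC2)cc1` carries methoxy in place of the fluoro of compound 2, on an aromatic carbon of a six-membered aromatic ring of carbon only, para to a large group: methoxy in place of fluoro on an aromatic carbon. Within the data shown here, the only measured step that bears on this change is a step that the two limits leave unreadable from compound 1 to compound 2, fluoro in place of hydrogen on an aromatic carbon. It offers no size to carry over, so no step beyond the scatter is expected in this assay. The expected step is a step that the limit leaves unreadable from compound 2 to compound 3. For compound 3 the estimate is 100 ug/mL, with an expected range from 40 ug/mL to 250 ug/mL, and another report as a limit is the likeliest outcome.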

Compound 3, half-maximal inhibitory concentration: > 64 ug/mL
Compound 3 ended at the assay's limit; the forecaster's own chance of this, stated with the estimate: 85%; the middle value lies beyond the limit too.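

No step can be read from compound 1, compound 2 or compound 3 in this assay, as each result is a limit of the assay and not a number: the limit of > 64 ug/mL in this assay, at which 3 of the 3 values shown sit.

The compounds shown leave open how much cytotoxicity any of the three has, and whether hydrogen, fluoro or methoxy on the aromatic carbon makes any difference.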